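A few compounds are considered here, and "the series" means these few. Any claim that something is new, unique, unknown or untested is made for them only; others in the source may bear on it.

Values in an ADME assay on the whole organism (Rattus norvegicus, strain Wistar Han) for pharmacokinetics, read by LC-MS, with stated times of 1 h and 7 h, at a dose of 1 mg/kg by the intravenous route; on this read-out higher numbers stand for fast clearance and lower numbers for slow clearance

Compound 1 `CNC(=O)c1cc(C(=O)N[C@@H]2C[C@H]2CO)cc2c1O[C@H](CF)[C@H]2c1ccccc1` gives 98 mL/min/kg
Compound 2 `CNC(=O)c1cc(C(=O)NC2CC2)cc2c1O[C@H](CO)[C@H]2c1ccccc1` gives 74 mL/min/kg
Compound 3 `CNC(=O)c1cc(C(=O)NCCC[C@H]2OC[C@H](N)CO2)cc2c1O[C@H](CF)[C@H]2c1ccccc1` gives 73 mL/min/kg

Compound 2, at 74 mL/min/kg, lies within the scatter of both other compounds, so these three values show no order among them. Compound 4 `CNC(=O)c1cc(C(=O)NC2CC2)cc2c1O[C@H](C)[C@H]2c1ccccc1` departs from compound 2 in one place, (hydrogen in place of hydroxy on a saturated chain carbon bound to a saturated ring carbon), which is hydrogen in place of hydroxy on a saturated chain carbon bound to a saturated ring carbon, or hydroxymethyl to methyl. Within the data shown here, no measured step covers this change. Among the measured compounds shown here, the only step measured between compounds that differ in one place, a 1.3-fold lower number from compound 1 to compound 3 (0.13 log units; within the scatter), concerns a different group, on an amide-type nitrogen, and it stays within the scatter. It therefore offers only indirect guidance, and it gives no direction for the change in compound 4. With that step so small and compound 2 as the closest reference, clearance is expected to shift by no more than the scatter. The estimated change is a 1.0-fold lower number from compound 2 to compound 4 (0.01 log units; within the scatter), a step that is not expected to be distinguishable from repeat variation. For compound 4 the expected clearance is 72 mL/min/kg, with an estimated range from 42 mL/min/kg to 115 mL/min/kg.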

Compound 4, clearance: 90 mL/min/kg
The estimate for compound 4 lay 1.3-fold (0.10 log units) below the measured number; measured number inside the range.
By their numbers in this assay, from the lowest: compounds 3, 2, 4 and 1 (each within the scatter of the next).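

In this assay, the change from hydroxymethyl to methyl now has a measured step of its own (a 1.2-fold higher number from compound 2 to compound 4 (0.09 log units; within the scatter)). Among these compounds, the only step available from the earlier compounds concerned a group on an amide-type nitrogen. At this place, on a saturated chain carbon bound to a saturated ring carbon, hydroxy and its one hydrogen-bond donor and one hydrogen-bond acceptor gave way to hydrogen without a change in clearance that stands out from repeat variation, so this pair shows no sign that the hydroxy matters for this read-out. No measured evidence is available to explain this result.

On these data alone, the step comes from one pair on a cyclopropyl amide, and compound 1 and compound 3 differ from compound 2 in more than one place, so whether the same change behaves alike with another group on the amide-type nitrogen remains open. As far as these compounds go, it is also open whether an amine, a carboxylic acid or a longer chain at this place would move clearance by more than the scatter.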